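The compounds below may be only part of what the source reports. "The series", "measured", "known", "first", "only" and "open" are said of these compounds alone.

Measured so far:
compound 1 `CCOC(=O)C1=C(C)NC(C)=C(C(=O)OCC)C1c1c(-c2ccc(C(F)(F)F)cc2)nc2sccn12`: 150 nM
compound 2 `C=CCOC(=O)C1=C(C)NC(C)=C(C(=O)OCC=C)C1c1c(-c2ccc(C(F)(F)F)cc2)nc2sc(C)c(C)n12`: 8960 nM
compound 3 `C=CCOC(=O)C1=C(C)NC(C)=C(C(=O)OCC=C)C1c1c(-c2ccc(OC(F)(F)F)cc2)nc2sccn12`: 1970 nM

All three compounds were tested in a functional assay on cardiac atrium (Cavia porcellus); on this read-out lower numbers stand for an effect already at smaller amounts and higher numbers for an effect only at larger amounts of compound. Compound 1 has the lowest number of the three. Compound 3, at 1970 nM, stands above it by more than the scatter, and compound 2, at 8960 nM, stands higher still. No two of these compounds differ in one place only, so the data hold no direct measure of what exchanging a single group does.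

Compound 4 `CCOC(=O)C1=C(C)NC(C)=C(C(=O)OCC)C1c1c(-c2ccc(Cl)c(Cl)c2Cl)nc2sccn12` keeps the core of compound 1 and changes one group: 2,3,4-trichlorophenyl in place of 4-(trifluoromethyl)phenyl on an aromatic carbon. The new group sits on the same aromatic carbon of the five-membered aromatic ring, and it again holds one six-membered aromatic ring of carbon only.

Going by the values given here, with compound 1 at 150 nM, the lowest number so far, a change in this group seems more likely to raise the number than to lower it, although nothing measured fixes the size. In this assay a moderate upward step is expected, estimated as a 2.7-fold higher number from compound 1 to compound 4 (0.43 log units; beyond the scatter). The range is kept wide and reaches back to the level of compound 1. For compound 4 the expected value is 400 nM, with an estimated range from 90 nM to 1800 nM.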

Compound 4, half-maximal effective concentration: 610 nM
The estimate for compound 4 lay 1.5-fold (0.18 log units) below the measured number; measured number inside the range.
By their numbers in this assay, from the lowest: compound 1; then compound 4; then compound 3; then compound 2.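

In this assay, going by these compounds alone, replacing 4-(trifluoromethyl)phenyl with 2,3,4-trichlorophenyl on the aromatic carbon of the five-membered aromatic ring gives a 4.1-fold higher number from compound 1 to compound 4 (0.61 log units; beyond the scatter), and this is the first comparison in the set in which only one place differs. It shows that the read-out responds to a change at this position even with the core of compound 1 unchanged and with both groups holding one six-membered aromatic ring of carbon only, no hydrogen-bond donors or acceptors and no net charge. The available data offer no independent measurement that could explain this step.

Because the two groups differ in both their halogen and their substitution, this single exchange cannot show whether the step follows from losing trifluoromethyl, from introducing the three chlorines, or from where those chlorines sit. The compounds shown also leave open how a plain phenyl group, or a phenyl group carrying an amine or a carboxylic acid, would read at this position, and what the allyl esters and the two added methyl groups contribute on their own.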